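Moving the chlorine on the benzyl group of compound 3

The source may hold more compounds than are shown below. What is called first, only, known or untested is meant among the compounds shown, and "the series" means these compounds.

Measured compounds:
- compound 1, `COc1ccc(C2N=C(SCc3cccc(Cl)c3)NC(C)=C2C(=O)Nc2ccc(F)cc2)cc1OC`: 10.8%
- compound 2, `CC1=C(C(=O)Nc2ccc(F)cc2)C(c2ccc([N+](=O)[O-])cc2)N=C(SCc2ccccc2)N1`: 18%
- compound 3, `CC1=C(C(=O)Nc2ccc(F)cc2)C(c2ccc([N+](=O)[O-])cc2)N=C(SCc2ccccc2Cl)N1`: 8.8%

All three were tested in a functional assay on the whole organism (artery, strain albino) with Rattus norvegicus as the target, with a stated time of 120 min, at a dose of 10 mg/kg by the oral route; a higher number here means more inhibition at the dose given (going by the name of the read-out), a lower number less inhibition. Compound 3 gives the lowest of the three numbers, but its gap to compound 1 and to compound 2 both lie within the scatter, so no order among them can be claimed. Within the data shown here, the one measured step, a number 9.2 percentage points lower from compound 2 to compound 3 (within the scatter), is also within the scatter.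

Compound 4, `CC1=C(C(=O)Nc2ccc(F)cc2)C(c2ccc([N+](=O)[O-])cc2)N=C(SCc2cccc(Cl)c2)N1`, differs from compound 3 in one place: 3-chlorophenyl in place of 2-chlorophenyl on a saturated chain carbon bound to a sulfur. Among the measured compounds shown here, no measured pair shows exactly this change. Compound 1 carries the same 3-chlorobenzyl group as compound 4 but a different aryl group on the shared core, and in this assay compound 1 gives 10.8%, close to compound 3. Since the step of a number 9.2 percentage points lower from compound 2 to compound 3 (within the scatter) stayed within the scatter, the expected step of a number 3.2 percentage points higher from compound 3 to compound 4 (within the scatter) is also within the scatter, in no clear direction. Compound 4 is therefore estimated at 12%, with a range from 4% to 22%.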

Compound 4, a percentage reported as inhibition, in the whole organism at one dose (the size of the read-out at that dose, not a potency): 9.8%
The estimate for compound 4 lay 2.2 percentage points above the measured number, and the stated range covers the measured number.
By their numbers in this assay, from the lowest: compounds 3, 4, 1 and 2 (each within the scatter of the next).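

Moving the chlorine from 2-chlorobenzyl to 3-chlorobenzyl in this assay gives a number 1 percentage points higher from compound 3 to compound 4 (within the scatter), the first direct reading of this change, and it shows no difference that can be told from the scatter. Adding the chlorine at this new place gives a number 8.2 percentage points lower from compound 2 to compound 4 (within the scatter), and exchanging the aryl group on the saturated ring carbon gives a number 1 percentage points lower from compound 1 to compound 4 (within the scatter), so neither of these steps can be read as a real difference either. The data shown offer no measurement that could explain these numbers.

Going by these compounds, it remains open whether any change on the benzyl group can move the number beyond the scatter. A 4-chlorobenzyl group, an amine or a carboxylic acid on that ring, or a longer chain in place of the benzyl group would each test this.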